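Moving the chlorine on a chlorophenyl group

A few compounds are considered here, and "the series" means these few. Any claim that something is new, unique, unknown or untested is made for them only; others in the source may bear on it.

Compound 1 `COc1ccc(/C=C/C(=O)c2ccc(OC)c3c2OC(C)(C)C=C3)c(F)c1` gives > 10000 nM as a limit
Compound 2 `COc1ccc(C(=O)/C=C/c2ccc(N(C)C)cc2)c2c1C=CC(C)(C)O2` gives 1870 nM as a number
Compound 3 `COc1ccc(C(=O)/C=C/c2cccc(Cl)c2)c2c1C=CC(C)(C)O2` gives > 10000 nM as a limit

All three compounds were tested in a functional assay on HT-29 cells (Homo sapiens) for antiproliferative activity, read by MTT assay, with a stated time of 24 h (a lower number here means a stronger inhibitor, a higher number a weaker inhibitor), and share one core. They differ in the group on a double-bonded chain carbon bound to a double-bonded chain carbon. Compound 3 stands at the limit of > 10000 nM in this assay, at which 2 of the 3 values shown sit, and so has only a limit, not a number.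

Compound 4 `COc1ccc(C(=O)/C=C/c2ccccc2Cl)c2c1C=CC(C)(C)O2` has the same atoms as compound 3, joined differently, with 2-chlorophenyl in place of 3-chlorophenyl (the change in full: 2-chlorophenyl in place of 3-chlorophenyl on a double-bonded chain carbon bound to a double-bonded chain carbon).

Going by the values given here, no measured step makes this exact move, so the evidence is indirect. One readable step is an at least 5.3-fold higher number from compound 2 to compound 3 (0.72 log units; beyond the scatter) and it involves 4-(dimethylamino)phenyl, as does an at least 5.3-fold lower number from compound 1 to compound 2 (0.72 log units; beyond the scatter) with the same size. The remaining step is a step that the two limits leave unreadable from compound 1 to compound 3 and gives no size.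

Compound 3 carries a chlorophenyl group and gives > 10000 nM as a limit, so no clear gain is expected from the move in this assay and another limit is the likeliest report. The step expected is therefore no readable change (estimated as a step that the limit leaves unreadable from compound 3 to compound 4). Compound 4 is estimated at 12000 nM (expected range 4000 nM to 30000 nM).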

Compound 4, half-maximal inhibitory concentration: > 10000 nM
Compound 4 was reported as a limit; the forecaster's own chance of this, stated with the estimate: 75%; the middle value is on the limit's open side.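

Moving the chlorine from 3-chlorophenyl to 2-chlorophenyl does not bring compound 4 into the readable range of this assay, so neither chlorophenyl group shown yields a number. Set against compound 2, the only compound here with a number, the change to 2-chlorophenyl gives an at least 5.3-fold higher number from compound 2 to compound 4 (0.72 log units; beyond the scatter), which extends to a second chlorophenyl group what compound 3 already showed; the steps from compound 3 and from compound 1 to compound 4 join two limits and cannot be read. Among the compounds shown, only the 4-(dimethylamino)phenyl group of compound 2 gives a number, and the others all stop at one shared reading: the limit of > 10000 nM in this assay, at which 3 of the 4 values shown sit.

The compounds shown do not tell whether compound 3 and compound 4 differ at all, as both are reported only as limits. Going by these compounds alone, also open is whether a phenyl group carrying a plain amine or a carboxylic acid, on the same double-bonded chain carbon, would give a number in this assay, and how that number would compare with the one for compound 2.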